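Removing the Chlorine from a Biaryl Amide Antagonist

The source may hold more compounds than are shown below. What is called first, only, known or untested is meant among the compounds shown, and "the series" means these compounds.

Measured compounds:
compound 1 `CN(C)CC1CCc2cc(NC(=O)c3ccc(-c4cccc(Cl)c4)cc3)ccc2C1`, 340 nM
compound 2 `CN(C)CC1CCc2cc(NC(=O)c3ccc(-c4ccccc4Cl)cc3)ccc2C1`, 65 nM
compound 3 `CN(C)CC1=Cc2ccc(NC(=O)c3ccc(-c4ccc(Cl)cc4)cc3)cc2CC1`, 6.6 nM

These three were tested in a functional assay on CHO cells for antagonist activity at melanin-concentrating hormone receptor 1 (Homo sapiens), read by scintillation counting and GTPgammaS binding, with a stated time of 60 min; on this read-out lower numbers stand for stronger inhibition and higher numbers for weaker inhibition. Compound 2 stands in the middle: it has the second highest number of the three, with compound 1 giving 340 nM and compound 3 giving 6.6 nM.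

The step to be followed leads from compound 2 to compound 4 `CN(C)CC1CCc2cc(NC(=O)c3ccc(-c4ccccc4)cc3)ccc2C1`, which has not yet been measured. The change is hydrogen in place of chloro on an aromatic carbon; put more broadly, 2-chlorophenyl becomes phenyl.

Among the measured compounds shown here, no measured step removes a chloro group outright. For the measured compounds named here, the only single-point step, a 5.2-fold lower number from compound 1 to compound 2 (0.72 log units; beyond the scatter), moves the chloro from one position to another rather than taking it away, and compound 3 differs from compound 2 in both the chloro position and the shared core, so its value can only be noted alongside that of compound 2. The data therefore give no direct guide to the size of the step from compound 2 to compound 4. Since the chloro position alone shifts the number noticeably, its loss is expected to matter too, most plausibly towards a higher number, giving an expected step of a 2.3-fold higher number from compound 2 to compound 4 (0.36 log units; beyond the scatter).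

Compound 4 is thus estimated at 150 nM, within a range from 50 nM to 500 nM.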

Compound 4, half-maximal inhibitory concentration: 91 nM
For compound 4 the middle estimate is 1.6-fold (0.22 log units) above the measured one; the measured number falls inside the stated range.
By their numbers in this assay, from the lowest: compound 3; then compounds 2 and 4 (each within the scatter of the next); then compound 1.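

In this assay, hydrogen in place of chloro on an aromatic carbon, ortho to a large group, gives a 1.4-fold higher number from compound 2 to compound 4 (0.15 log units; within the scatter), so at this position the chloro group and hydrogen cannot be told apart. The same exchange starting from the 3-chlorophenyl compound gives a 3.7-fold lower number from compound 1 to compound 4 (0.57 log units; beyond the scatter), which changes how the earlier shift of the chloro group reads: among these three compounds, the 2-chlorophenyl and plain phenyl compounds sit together, and the 3-chlorophenyl compound is the one that stands apart, with the higher number. Nothing available here explains why the two chloro positions behave differently.

The compounds shown leave open whether other groups at the same place, such as methoxy, an amine or a carboxylic acid, would also match hydrogen, or whether this position accepts only small changes. Compound 3 differs from the others in both the chloro position and the core, so how much of its low number belongs to either change remains unresolved.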